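The source may report more compounds than this note shows. Statements on the series, on what has been measured and on what is new or still open speak of the compounds shown alone.

Measured compounds:
compound 1, `COC(=O)c1ccccc1-c1ccc([C@@H](C)Nc2nccc(C)c2NC(=O)CC#N)cc1`, gives 18.5 mL/min/kg in an in vivo ADME assay on the whole organism (Rattus norvegicus, strain Sprague Dawley) for pharmacokinetics; a lower number here means slower removal, a higher number faster removal of the compound;
compound 2, `CNC(=O)c1ccccc1-c1ccc([C@@H](C)Nc2nccc(C)c2NC(=O)CC(F)(F)F)cc1`, gives 31 mL/min/kg in this assay;
compound 3, `COC(=O)c1ccccc1-c1ccc(CNc2nccc(C)c2NC(=O)CC(F)(F)F)cc1`, gives 14 mL/min/kg in this assay.

Among these three numbers, compound 3 stands at the lowest. Compound 1 is the nearest to it, and the gap between the two lies within the usual scatter, so no order can be read between them. Compound 2 is the furthest, and its gap to compound 3 lies beyond the scatter.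

The step from compound 3 leads to compound 4, `COC(=O)c1ccccc1-c1ccc([C@@H](C)Nc2nccc(C)c2NC(=O)CC(F)(F)F)cc1`. The change is methyl in place of hydrogen on a saturated chain carbon bound to an aromatic carbon and a nitrogen on an aromatic ring. For the measured compounds named here, no measured pair in this set differs by exactly this change, so its effect in this assay has not been seen directly. Compound 1 carries the same methyl on that carbon, with a different group on the amide, and gives 18.5 mL/min/kg, which sits within the scatter of compound 3. On that basis the step from compound 3 to compound 4 is expected to be small, a 1.3-fold higher number from compound 3 to compound 4 (0.11 log units; within the scatter), and not clearly beyond the scatter in either direction. Compound 4 is therefore estimated at 18 mL/min/kg, with a range from 9 mL/min/kg to 36 mL/min/kg.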

Compound 4, clearance: 8 mL/min/kg
The estimate for compound 4 lay 2.3-fold (0.35 log units) above the measured number; measured number below the stated range.
By their numbers in this assay, from the lowest: compounds 4, 3, 1 and 2 (each within the scatter of the next, the first and the last beyond it).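

In this assay, methyl in place of hydrogen on the saturated chain carbon bound to an aromatic carbon and a nitrogen on an aromatic ring gives a 1.8-fold lower number from compound 3 to compound 4 (0.24 log units; within the scatter), so this first direct pair shows no readable effect of the change at this position. Compound 4 also makes two changes elsewhere readable against a background that carries this methyl: methoxy in place of methylamino on a carbonyl carbon gives a 3.9-fold lower number from compound 2 to compound 4 (0.59 log units; beyond the scatter), and trifluoromethyl in place of cyano on a saturated chain carbon bound to a carbonyl carbon gives a 2.3-fold lower number from compound 1 to compound 4 (0.36 log units; beyond the scatter), both beyond the scatter though modest. Nothing available here accounts for any of these steps.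

The compounds shown leave open whether the methyl step would read the same in a compound carrying methylamino on the carbonyl carbon or cyano on the amide side. Going by these compounds, how an ethyl on the saturated chain carbon, or a hydroxyl in place of methoxy on the carbonyl carbon, would read in this assay also remains open.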